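The source may hold more compounds than are shown below. What is called first, only, known or untested is meant among the compounds shown, and "the series" means these compounds.

Measured so far in an ADME assay on microsomes from liver (Homo sapiens) for metabolic stability, with a stated time of 30 min; a lower number here means that less of the compound is left, a higher number that more of the compound is left:

compound 1 `CCCCc1nc(C(C)C)c(CC(=O)OC2CC2)c(=O)n1Cc1ccc(-c2ccccc2-c2noc(=O)[nH]2)cc1` gives 10.3%
compound 2 `CC#CCOC(=O)Cc1c(C(C)C)nc(CCCC)n(Cc2ccc(-c3ccccc3-c3noc(=O)[nH]3)cc2)c1=O` gives 13.7%
compound 3 `CCCCc1nc(C)c(CC(=O)OC)c(=O)n1Cc1ccc(-c2ccccc2-c2noc(=O)[nH]2)cc1` gives 69.6%

Compound 3 stands highest of the three, beyond the scatter from both others. Compound 4 `CCCCc1nc(C)c(CC(=O)OCC2CCCCC2)c(=O)n1Cc1ccc(-c2ccccc2-c2noc(=O)[nH]2)cc1` differs from it by cyclohexyl in place of hydrogen on a saturated chain carbon bound to an oxygen next to a carbonyl group. Among the measured compounds shown here, the only single step among the measured compounds that also reshapes this ester group is a number 3.4 percentage points higher from compound 1 to compound 2 (within the scatter), a change that stayed within the scatter. Compounds 1 and 2 differ from compound 3 in two places at once, so their far lower numbers cannot be tied to the ester alone. On that thin basis a drop is expected but with little confidence, estimated as a number 34.6 percentage points lower from compound 3 to compound 4 (beyond the scatter) in this assay. Compound 4 is therefore expected to give about 35%, plausibly between 8% and 65%.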

Compound 4, percent of the compound remaining: 11.5%
For compound 4 the middle estimate is 23.5 percentage points above the measured one; measured number inside the range.
By their numbers in this assay, from the lowest: compounds 1, 4 and 2 (each within the scatter of the next); then compound 3.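

In this assay, among the compounds shown here, a number 58.1 percentage points lower from compound 3 to compound 4 (beyond the scatter) is a large step, and cyclohexyl on the saturated chain carbon bound to an oxygen next to a carbonyl group is the only change. This shows that the ester end alone can greatly alter how much compound is left, whereas a number 3.4 percentage points higher from compound 1 to compound 2 (within the scatter) gave no sign of this. Nothing shown here explains the drop.

Going by these compounds, what stays open is whether the ring itself matters or whether a longer chain such as hexyl would do the same. How an ethyl ester or a carboxylic acid at this place would behave is also unknown.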